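This account rests on a few compounds, and the source may have more. Where it says the series, first, only, none or still open, it means among the compounds named here.

Working notes on the ester-to-amide question in this small series. Compound 3 `COC(=O)c1cc(N)c(Nc2ccc(C#N)cc2)cc1Oc1c(C)cc(/C=C/C#N)cc1C` sits at the low end: in an ADME assay on microsomes from liver (Homo sapiens) for metabolic stability, read by LC-MS, using NADPH, with a stated time of 45 min, tested at 1 uM (on this read-out lower numbers stand for a shorter-lived compound and higher numbers for a longer-lived compound), compound 3 gives 0.308 h, and compound 1 `COCCOC(=O)c1cc(N)c(Nc2ccc(C#N)cc2)cc1Oc1c(C)cc(/C=C/C#N)cc1C` gives 0.317 h, the two within the scatter, while compound 2 `CCNC(=O)c1cc(N)c(Nc2ccc(C#N)cc2)cc1Oc1c(C)cc(/C=C/C#N)cc1C` gives 2.32 h, as seen in a 7.5-fold lower number from compound 2 to compound 3 (0.88 log units; beyond the scatter). Compound 4 `CNC(=O)c1cc(N)c(Nc2ccc(C#N)cc2)cc1Oc1c(C)cc(/C=C/C#N)cc1C` differs from compound 3 by methylamino in place of methoxy on a carbonyl carbon, that is methoxycarbonyl to methylcarbamoyl. The measured steps that bear on this are a 7.5-fold lower number from compound 2 to compound 3 (0.88 log units; beyond the scatter) and, in the opposite sense, a 7.3-fold higher number from compound 1 to compound 2 (0.86 log units; beyond the scatter); both turn on the carbonyl substituent and lie beyond the scatter. A step of comparable size upward is therefore expected for compound 4, as a 6.5-fold higher number from compound 3 to compound 4 (0.81 log units; beyond the scatter). On that basis compound 4 is estimated at 2 h, within the range 0.9 h to 4.5 h.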

Compound 4, half-life in the liver assay: 1.87 h
The estimate for compound 4 lay 1.1-fold (0.03 log units) above the measured number; low and high end bracket the measured number.
By their numbers in the liver assay, from the lowest: compounds 3 and 1 (each within the scatter of the next); then compounds 4 and 2 (each within the scatter of the next).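

In the liver assay the step up on the carbonyl carbon does not depend on ethylamino: methylamino gives it too, in a 6.1-fold higher number from compound 3 to compound 4 (0.78 log units; beyond the scatter) and in a 5.9-fold higher number from compound 1 to compound 4 (0.77 log units; beyond the scatter), while a 1.2-fold lower number from compound 2 to compound 4 (0.09 log units; within the scatter) leaves the two amides level. In a physicochemical assay for solubility, read by HPLC, in phosphate buffer, with a stated time of 4 h, at pH 7.4 (on this read-out higher numbers stand for higher solubility and lower numbers for lower solubility), compound 3 gives 1.21 ug/mL and compound 4 gives 8.28 ug/mL. The same change also shows in the physicochemical assay as well: the measured solubility of compound 3, 1.21 ug/mL, and of compound 4, 8.28 ug/mL, a 6.8-fold higher number (0.84 log units; beyond the scatter).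

Going by these compounds, whether the half-life holds with a longer chain on the amide nitrogen, or with dimethylamino, which lacks the amide hydrogen, stays open. On these data alone, whether solubility follows the same order across the other carbonyl substituents also stays open.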